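Swapping the Sulfonyl Aryl Group in an EP3 Antagonist Series

This account rests on a few compounds, and the source may have more. Where it says the series, first, only, none or still open, it means among the compounds named here.

Of the compounds shown here, three sharing one core have been measured in a functional assay on CHO-K1 cells for antagonist activity at prostaglandin E2 receptor EP3 subtype (Homo sapiens), read by TR-FRET and cAMP accumulation, with a stated time of 30 min; a higher number here means a weaker inhibitor, a lower number a stronger inhibitor. Compound 1 `Cn1cc(S(=O)(=O)NC(=O)NC/C=C2\CCCc3cnn(Cc4ccc(Cl)cc4Cl)c32)cn1` gives 8 nM. Compound 2 `O=C(NC/C=C1\CCCc2cnn(-c3ccc(C(F)(F)F)cc3)c21)NS(=O)(=O)c1cc(Cl)c(Cl)s1` gives 4 nM. Compound 3 `O=C(NS(=O)(=O)c1ccc(Cl)cc1)OC/C=C1\CCCc2cnn(Cc3ccc(Cl)cc3Cl)c21` gives 92 nM. Among these three numbers, compound 1 stands second highest. Its nearest neighbour is compound 2, whose number lies within the usual scatter, so the two cannot be told apart. Its furthest neighbour is compound 3, whose number lies beyond the scatter, so compound 3 is the weaker inhibitor of that pair; compound 3 differs from compound 1 in more than one place, so that gap cannot be tied to a single change.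

Compound 4 `COc1ccccc1S(=O)(=O)NC(=O)NC/C=C1\CCCc2cnn(Cc3ccc(Cl)cc3Cl)c21` has not yet been measured. It differs from compound 1 in one place: 2-methoxyphenyl in place of 1-methyl-1H-pyrazol-4-yl on a sulfonyl sulfur. Among the measured compounds shown here, no pair of measured compounds shows this kind of change alone, so there is no measured step to lean on. Compound 1 and compound 2 carry different aromatic groups on the sulfonyl sulfur and give numbers within the scatter of each other, which hints that varying this group need not shift the number greatly. The step from compound 1 to compound 4 is therefore expected to be a 1.5-fold higher number from compound 1 to compound 4 (0.18 log units; within the scatter), modest and possibly towards a somewhat weaker inhibitor, but not clearly beyond the scatter. Compound 4 is estimated at 12 nM, within a range from 4 nM to 40 nM.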

Compound 4, half-maximal inhibitory concentration: 114 nM
For compound 4 the middle estimate is 9.5-fold (0.98 log units) below the measured one; the measured number lies above the stated range.
By their numbers in this assay, from the lowest: compounds 2 and 1 (each within the scatter of the next); then compounds 3 and 4 (each within the scatter of the next).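

In this assay replacing 1-methyl-1H-pyrazol-4-yl with 2-methoxyphenyl on a sulfonyl sulfur gives a 14-fold higher number from compound 1 to compound 4 (1.15 log units; beyond the scatter) and makes compound 4 a clearly weaker inhibitor than compound 1. Among the compounds shown here, this is the first change measured at this position on its own, and it shows that the group on this sulfur can strongly affect the result. The closeness of compound 1 and compound 2 had not shown this, since those two also differ elsewhere, and nothing measured here explains the size of the step.

On these data alone, it remains open whether the loss goes with the methoxy group or with the six-membered carbon ring itself, and a plain phenyl group on the same sulfur, with the rest of compound 1 unchanged, would separate the two. As far as these compounds go, it is also open whether a different small ring, such as a pyridine or a thiophene, would stay close to compound 1 or fall away as compound 4 does.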